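A few compounds are considered here, and "the series" means these few. Any claim that something is new, unique, unknown or untested is made for them only; others in the source may bear on it.

Working notes on the series, all sharing the core of compound 1 `C#CCOc1cc(/C=C/C(=O)c2ccc(OC)c3c2OC(C)(C)C=C3)ccc1OC`. In a functional assay on A-375 cells (Homo sapiens) for cytotoxicity, read by MTT assay (on this read-out lower numbers stand for stronger inhibition and higher numbers for weaker inhibition), compound 1 gives > 10000 nM, which is a limit of the assay and not a number. Compound 2 `CCC(=O)Oc1cc(/C=C/C(=O)c2ccc(OC)c3c2OC(C)(C)C=C3)ccc1OC` gives 240 nM in this assay. Compound 3 `CCCCC(=O)Oc1cc(/C=C/C(=O)c2ccc(OC)c3c2OC(C)(C)C=C3)ccc1OC` stands at 220 nM, level with compound 2 within the scatter: a 1.1-fold lower number from compound 2 to compound 3 (0.04 log units; within the scatter). Both sit far from the propargyl compound, with an at least 41-fold lower number from compound 1 to compound 2 (1.61 log units; beyond the scatter) and an at least 45-fold lower number from compound 1 to compound 3 (1.65 log units; beyond the scatter).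

Compound 4 `C=CC(=O)Oc1cc(/C=C/C(=O)c2ccc(OC)c3c2OC(C)(C)C=C3)ccc1OC` is the next one to read. Its change from compound 3 is vinyl in place of butyl on a carbonyl carbon, which turns butylcarbonyl into vinylcarbonyl.

Going by the values given here, the two large steps replace propargyl on the oxygen, so they show only that the carbonyl-bearing groups differ from propargyl. The closer guide is the change of chain on the carbonyl, where compound 3 differs from compound 2 with a 1.1-fold lower number from compound 2 to compound 3 (0.04 log units; within the scatter). Among the compounds with values here, that step suggests little sensitivity to the chain, but it covers only two saturated groups, and no vinyl group has been measured here. As far as these compounds go, no step beyond the scatter is therefore expected in this assay, though a shift in either direction remains open. The estimate means a 1.1-fold higher number from compound 3 to compound 4 (0.04 log units; within the scatter), an expected step of no clear direction. For compound 4 the estimated value is 240 nM, with an expected range of 80 nM to 800 nM.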

Compound 4, half-maximal inhibitory concentration: 390 nM
For compound 4 the middle estimate is 1.6-fold (0.21 log units) below the measured one; measured number inside the range.
By their numbers in this assay, from the lowest: compounds 3, 2 and 4 (each within the scatter of the next). At a limit, above all of these: compound 1.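

In this assay, vinyl on the carbonyl carbon is not separated from either saturated chain (a 1.8-fold higher number from compound 3 to compound 4 (0.25 log units; within the scatter); a 1.6-fold higher number from compound 2 to compound 4 (0.21 log units; within the scatter)), so the insensitivity seen between ethyl and butyl now extends to a group with a double bond outside aromatic rings. Compound 4 also stays apart from the propargyl ether, with vinylcarbonyl on the same oxygen (an at least 25-fold lower number from compound 1 to compound 4 (1.40 log units; beyond the scatter)), which gives a third carbonyl-bearing group on the far side of that large step. The size of that step is only a bound, since compound 1 stands at a limit of the assay and not at a number: the limit of > 10000 nM in this assay, at which 1 of the 4 values shown sits.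

As far as these compounds go, whether this flat reading holds for a much longer chain, a phenyl group or an amine on the carbonyl carbon remains open. Also open, from the compounds shown here alone, is what a free hydroxyl or a plain methyl ether on the same oxygen would give, so the three esters cannot yet show whether the difference from compound 1 follows from the carbonyl group or from the absence of propargyl.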